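This account rests on a few compounds, and the source may have more. Where it says the series, first, only, none or still open, it means among the compounds named here.

Compound 1 `CSc1ncc2cc(-c3ccccc3)c(-c3ccc(CNCCC(N)=O)cc3)nc2n1`: 226 nM in an assay on isolated protein for inhibition of RAC-alpha serine/threonine-protein kinase (Homo sapiens); a higher number here means a weaker inhibitor, a lower number a stronger inhibitor
Compound 2 `CSc1ncc2cc(-c3ccccc3)c(-c3ccc(CNCCCN4CCN(C)CC4)cc3)nc2n1`: 765 nM in this assay

Among the measured compounds shown here, compound 2 stands highest of the two numbers; its only neighbour is compound 1, reached through a 3.4-fold higher number from compound 1 to compound 2 (0.53 log units; beyond the scatter). Compound 3 `CSc1ncc2cc(-c3ccccc3)c(-c3ccc(CNCCCn4ccnc4)cc3)nc2n1` carries 1H-imidazol-1-yl in place of 4-methylpiperazin-1-yl on a saturated chain carbon, three bonds along the chain from an amine nitrogen. For the measured compounds named here, no measured pair shows this swap; the step from compound 1 to compound 2 only shows that an exchange of the group on that saturated chain carbon moves the number modestly. A step of similar or smaller size, direction uncertain, is therefore expected. Compound 3 is estimated at 500 nM, range 150 nM to 1600 nM. The expected step is a 1.5-fold lower number from compound 2 to compound 3 (0.18 log units; within the scatter).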

Compound 3, half-maximal inhibitory concentration: 137 nM
Compound 3: middle estimate off by 3.6-fold (0.56 log units), on the high side; the whole stated range lies above it.
By their numbers in this assay, from the lowest: compounds 3 and 1 (each within the scatter of the next); then compound 2.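

In this assay, the exchange on the saturated chain carbon, three bonds along the chain from an amine nitrogen, gives a 5.6-fold lower number from compound 2 to compound 3 (0.75 log units; beyond the scatter) and so shows that this place responds to the choice of ring. Among the compounds shown here, with (1H-imidazol-1-yl)methyl in place of carbamoyl there is a 1.6-fold lower number from compound 1 to compound 3 (0.22 log units; within the scatter) and no separation between these two groups, leaving 4-methylpiperazin-1-yl as the one group of the three with a distinctly higher number. No supporting measurement bears on why the ring exchange shifts the number. Left open is whether a morpholin-4-yl ring or a carboxylic acid at this place would follow compound 2 or compound 3. Also open, going by these compounds, is whether a longer chain carrying 1H-imidazol-1-yl would keep the number of compound 3.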